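Carbamate Chain Length in a Shared Indoline-Derived Series

The source may report more compounds than this note shows. Statements on the series, on what has been measured and on what is new or still open speak of the compounds shown alone.

Compound 1 `CC(C)OC(=O)N1CCC(Oc2cccc3c2CCN3c2ccc(S(C)(=O)=O)cc2)CC1`: 501 nM
Compound 2 `CC(C)(C)OC(=O)N1CCC(Oc2cccc3c2CCN3c2ccc(S(C)(=O)=O)cc2)CC1`: 158 nM
Compound 3 `CCOC(=O)N1CCC(Oc2ncnc3c2CCN3c2ccc(S(C)(=O)=O)cc2F)CC1`: 251 nM

All three were tested in a functional assay on CHO-K1 cells for agonist activity at Glucose-dependent insulinotropic receptor (Homo sapiens), read by a luciferase reporter, with a stated time of 5 h; on this read-out higher numbers stand for an effect only at larger amounts of compound and lower numbers for an effect already at smaller amounts. Compound 1 and compound 2 share one core; compound 3 has a different core, and the difference between the two cores is not broken down here. Compound 2 differs from compound 1 by methyl in place of hydrogen on a saturated chain carbon bound to an oxygen next to a carbonyl group and two saturated chain carbons, and that change gave a 3.2-fold lower number from compound 1 to compound 2 (0.50 log units; beyond the scatter). Compound 3 sits between the two with a number within the scatter of both.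

Compound 4 `CCCOC(=O)N1CCC(Oc2ncnc3c2CCN3c2ccc(S(C)(=O)=O)cc2F)CC1` has not yet been measured. It differs from compound 3 by methyl in place of hydrogen on a saturated chain carbon, two bonds along the chain from an oxygen next to a carbonyl group. This is the same kind of change as that from compound 1 to compound 2, not the same: there the methyl entered on a saturated chain carbon bound to an oxygen next to a carbonyl group and two saturated chain carbons, whereas here it enters on a saturated chain carbon two bonds along the chain from that oxygen, and the cores differ.

Compound 4 is expected to give a 1.6-fold lower number from compound 3 to compound 4 (0.20 log units; within the scatter), a step resting on compound 2, because a 3.2-fold lower number from compound 1 to compound 2 (0.50 log units; beyond the scatter) showed a gain, tempered by the different place and core. The estimate for compound 4 is 160 nM, within 60 nM to 400 nM.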

Compound 4, half-maximal effective concentration: 79.4 nM
Estimate against measurement, compound 4: 2.0-fold (0.30 log units) above, within the range that was stated.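

In this assay, methyl in place of hydrogen on a saturated chain carbon, two bonds along the chain from an oxygen next to a carbonyl group, gave a 3.2-fold lower number from compound 3 to compound 4 (0.50 log units; beyond the scatter), and set beside the earlier step on the other core, the two agree: the same change on two cores in this assay, a 3.2-fold lower number (0.50 log units; beyond the scatter) from compound 1 to compound 2 and a 3.2-fold lower number (0.50 log units; beyond the scatter) from compound 3 to compound 4, 1.0-fold (0.00 log units) apart, within the scatter of two such steps

Within these four compounds, then, adding one methyl to the carbamate chain lowered the number by a like amount on each core, with no compound going against this. Among the compounds shown here, it does not show that the step transfers in a strict sense, since each core offers only one pair and the methyl enters at a different place in each pair, so the agreement cannot separate the effect of the core from that of the place.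

The compounds shown leave open whether a longer chain, such as butyl, would lower the number further on either core. They also leave open how the branched carbamates of compound 1 and compound 2 would read on the core of compound 3, and how a propyl carbamate would read on the core of compound 1.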